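Swapping the Group on the Ring Nitrogen of Compound 2

The source may report more compounds than this note shows. Statements on the series, on what has been measured and on what is new or still open speak of the compounds shown alone.

Compound 1 `Nc1ccccc1NC(=O)c1ccc(CSC(=S)N2CCN(c3cccnc3)CC2)cc1` and compound 2 `N#Cc1ccc(N2CCN(C(=S)SCc3ccc(C(=O)Nc4ccccc4N)cc3)CC2)cc1` share one core and differ only on an amine nitrogen in a ring. In a functional assay on HeLa cells (Homo sapiens) for antiproliferative activity, read by CCK-8 assay, with a stated time of 72 h, tested at 8 uM (on this read-out higher numbers stand for a stronger effect at the one concentration tested and lower numbers for a weaker effect), compound 1 gives 72.5%, and compound 2 gives 70.6%; the step of a number 1.9 percentage points lower from compound 1 to compound 2 (within the scatter) shows that this exchange left the read-out essentially unchanged. Compound 2 shows the lower of the two numbers, a gap that lies within the scatter. Compound 3 `Nc1ccccc1NC(=O)c1ccc(CSC(=S)N2CCN(Cc3cccnc3)CC2)cc1` carries (pyridin-3-yl)methyl in place of 4-cyanophenyl on an amine nitrogen in a ring. Within the data shown here, only the step from compound 1 to compound 2 bears on this change, and it was within the scatter. For compound 3 the expected step is therefore a number 2.6 percentage points lower from compound 2 to compound 3 (within the scatter) in this assay. Compound 3 is estimated at 68%, between 50% and 84%.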

Compound 3, a percentage reported as inhibition, at one concentration (the size of the read-out at that concentration, not a potency): 78%
Compound 3: middle estimate off by 10 percentage points, on the low side, within the range that was stated.
By their numbers in this assay, from the lowest: compounds 2, 1 and 3 (each within the scatter of the next).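

In this assay, the (pyridin-3-yl)methyl group on the amine nitrogen in the ring cannot be told apart from either earlier group: the data show a number 7.4 percentage points higher from compound 2 to compound 3 (within the scatter) and a number 5.5 percentage points higher from compound 1 to compound 3 (within the scatter). The position therefore holds the pyridin-3-yl ring with or without the added methyl link, and no difference beyond the scatter appears. Nothing measured here offers an explanation for these numbers.

Going by these compounds, whether a longer chain carrying the pyridin-3-yl, or a carboxylic acid on this nitrogen, would give a read-out beyond the scatter remains open. A single concentration also leaves the potency of all these compounds unknown.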